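The source may hold more compounds than are shown below. What is called first, only, known or untested is meant among the compounds shown, and "the series" means these compounds.

Compound 1 `C[C@@H](O)[C@H]1C(=O)N2C(C(=O)OCOC(=O)C3CCCCC3)=C(S[C@@H]3CN[C@H](C(=O)Nc4cccc(C(=O)O)c4)C3)[C@H](C)[C@H]12` carries a free carboxylic acid at one end and a ((cyclohexylcarbonyl)oxy)methyl ester at the other. In an ADME assay on a cell-free system (plasma, Homo sapiens) for metabolic stability, read by LC-MS, with a stated time of 60 min, at 37 degrees C, tested at 50 uM (a lower number here means that less of the compound is left, a higher number that more of the compound is left), compound 1 gives 20%, which is the second highest of the three measured numbers. Compound 2 `CCOC(=O)C1=C(S[C@H]2C[C@@H](C(=O)Nc3cccc(C(=O)OCC)c3)N(Cc3oc(=O)oc3C)C2)[C@H](C)[C@@H]2[C@@H]([C@@H](C)O)C(=O)N12` gives 19% in this assay, a value within the scatter of compound 1, so the two cannot be told apart. Among the measured compounds shown here, compound 3 `C[C@@H](O)[C@H]1C(=O)N2C(C(=O)OCOC(=O)C3CCCCC3)=C(S[C@@H]3CN[C@H](C(=O)Nc4cccc(C(=O)OCOC(=O)C5CCCCC5)c4)C3)[C@H](C)[C@H]12` gives 60%, and the step of a number 40 percentage points higher from compound 1 to compound 3 (beyond the scatter) is the one large measured change: ((cyclohexylcarbonyl)oxy)methyl in place of hydrogen on an oxygen next to a carbonyl group leaves much more of the compound behind.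

Compound 4 `CC(C)C(=O)OCOC(=O)C1=C(S[C@@H]2CN[C@H](C(=O)Nc3cccc(C(=O)O)c3)C2)[C@H](C)[C@@H]2[C@@H]([C@@H](C)O)C(=O)N12` differs from compound 1 at a different place: isopropyl in place of cyclohexyl on a carbonyl carbon. The free carboxylic acid of compound 1 stays as it is. For the measured compounds named here, no measured pair shows what isopropyl in place of cyclohexyl on a carbonyl carbon does in this assay; the only measured step, between compound 1 and compound 3, concerns another part of the molecule and so does not bear on this change. With nothing pointing either way, the expected step of a number 3 percentage points lower from compound 1 to compound 4 (within the scatter) is none beyond the scatter. Compound 4 is therefore estimated at 17%, within a range from 6% to 32%.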

Compound 4, percent of the compound remaining: 15%
For compound 4 the middle estimate is 2 percentage points above the measured one; low and high end bracket the measured number.
By their numbers in this assay, from the lowest: compounds 4, 2 and 1 (each within the scatter of the next); then compound 3.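

The earlier compounds shown here gave no reading at this position. Among the compounds shown here, their only measured step lay at the other end of the molecule. Now, in this assay with the free carboxylic acid left in place, isopropyl in place of cyclohexyl on a carbonyl carbon gives a number 5 percentage points lower from compound 1 to compound 4 (within the scatter) and so compound 1 and compound 4 cannot be told apart, which shows that in this pair the six-membered ring of carbon only can be exchanged for an open group with no change beyond the scatter. Nothing measured here speaks to the reason for this result.

For the compounds shown here, what stays open is whether another group on this carbonyl carbon, such as a longer straight carbon chain, a phenyl ring or a chain carrying an amine, would move the number beyond the scatter, since cyclohexyl and isopropyl are the only two groups compared here. Also open, from the compounds shown here alone, is whether isopropyl would behave the same way in a compound whose second acid is capped as an ester, as it is in compound 3, where much more of the compound is left.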